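The compounds below may be only part of what the source reports. "The series", "measured", "known", "first", "only" and "open" are said of these compounds alone.

In an ADME assay on liver for metabolic stability, with Liver microsome (Homo sapiens) as the target, read by LC-MS, using microsomes (on this read-out lower numbers stand for slow clearance and higher numbers for fast clearance), compound 1 `CC1(C[C@@H](O)C(=O)N2N=CC[C@H]2C(=O)NCc2cc(Cl)ccc2-n2cnnn2)CC1` gives < 12 mL.min-1.g-1, which is a limit of the assay and not a number. Compound 2 `CC(C)(C)[C@@H](O)C(=O)N1CSC(C)(C)[C@H]1C(=O)NCc1cc(Cl)ccc1-n1cnnn1` reads 360 mL.min-1.g-1 and compound 3 `CC(C)(C)C[C@@H](O)C(=O)N1CC[C@@H]2C[C@@]21C(=O)NCc1cc(Cl)ccc1-n1cnnn1` reads 27 mL.min-1.g-1, which leaves compound 1 at the slow-clearance end of the values shown. Compound 4 `CCCC[C@@H](O)C(=O)N1N=CC[C@H]1C(=O)NCc1cc(Cl)ccc1-n1cnnn1` keeps the core of compound 1 and differs by propyl in place of 1-methylcyclopropyl on a saturated chain carbon, two bonds along the chain from a carbonyl carbon and an oxygen on a saturated carbon: propyl in place of 1-methylcyclopropyl on a saturated chain carbon. Among the measured compounds shown here, no measured pair of compounds shows what such a change does, so the expectation is tentative. A modest rise in this assay is expected, estimated as an at least 1.5-fold higher number from compound 1 to compound 4 (0.17 log units; that floor lies within the scatter). For compound 4 the expected value is 18 mL.min-1.g-1, with an estimated range of 8 mL.min-1.g-1 to 45 mL.min-1.g-1.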

Compound 4, intrinsic clearance in microsomes: < 12 mL.min-1.g-1
Compound 4: a limit, no number; the forecaster's own chance of this, stated with the estimate: 35%; middle value at least 1.5-fold (0.17 log units) from the limit.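

Compound 1 and compound 4 both stand at a limit of the assay and not at a number, so no step can be read between them: the limit of < 12 mL.min-1.g-1 in this assay, at which 2 of the 4 values shown sit.

The compounds shown leave open whether propyl in place of 1-methylcyclopropyl changes clearance at all in this assay.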